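Working notes: the step from compound 1 to compound 4

This account rests on a few compounds, and the source may have more. Where it says the series, first, only, none or still open, it means among the compounds named here.

Values so far in an ADME assay on MT4 cells (Homo sapiens) for cytotoxicity (on this read-out higher numbers stand for lower toxicity in this test and lower numbers for higher toxicity in this test), are these.
- compound 1 `Cc1cc(C)cc(S(=O)(=O)n2c(SCC(=O)Nc3ccccc3Br)nc3ccccc32)c1` gives >= 235000 nM (a limit of the assay, not a number)
- compound 2 `Cc1cc(C)cc(S(=O)(=O)n2c(SCC(=O)Nc3ccccc3Br)nc3ccc(Cl)cc32)c1` gives 145000 nM
- compound 3 `Cc1cc(C)cc(Cn2c(SCC(=O)Nc3ccccc3[N+](=O)[O-])nc3ccc(Cl)cc32)c1` gives 131000 nM

Compound 1 stands at the limit of >= 235000 nM in this assay, at which 1 of the 3 values shown sits, and so has a limit and no number.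

Compound 4 `COC(=O)c1ccc(NC(=O)CSc2nc3ccccc3n2S(=O)(=O)c2cc(C)cc(C)c2)c(Cl)c1` is not yet measured. It keeps the core of compound 1 and differs in one group, 2-chloro-4-(methoxycarbonyl)phenyl in place of 2-bromophenyl on an amide-type nitrogen.

Among the measured compounds shown here, only one measured step is at hand, an at least 1.6-fold lower number from compound 1 to compound 2 (0.20 log units; that floor lies within the scatter), and it bears on this change only indirectly, since it is a chloro in place of hydrogen on an aromatic carbon and leaves the group on the amide-type nitrogen untouched. For the measured compounds named here, compound 3, which differs in that group and elsewhere, gives 131000 nM, within the scatter of compound 2 at 145000 nM and so adds no separate size of step.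

No step beyond the scatter is therefore expected in this assay in either direction. The estimated result is an at least 1.5-fold lower number from compound 1 to compound 4 (0.19 log units; that floor lies within the scatter) and remains an expectation until measured. Compound 4 is estimated at 150000 nM (expected range 70000 nM to 240000 nM).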

Compound 4, half-maximal cytotoxic concentration: 145000 nM
Compound 4: middle estimate off by 1.0-fold (0.01 log units), on the high side; measured number inside the range.
By their numbers in this assay, from the lowest: compounds 3, 2 and 4 (each within the scatter of the next). At a limit, above all of these: compound 1.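

In this assay, the first step read for the group on the amide-type nitrogen is an at least 1.6-fold lower number from compound 1 to compound 4 (0.20 log units; that floor lies within the scatter), for 2-chloro-4-(methoxycarbonyl)phenyl in place of 2-bromophenyl. The entering group brings a methoxycarbonyl group and a chlorine in place of the bromine, and the floor of this step still lies within the scatter, so the shared core with this larger group gives no step shown to lie beyond the scatter. That floor is all the step gives, and its true size stays unknown because compound 1 has a limit of the assay and not a number: the limit of >= 235000 nM in this assay, at which 1 of the 4 values shown sits.

The single exchange changes the halogen and adds the methoxycarbonyl group together, so the compounds shown do not separate the share of each in the step, and they do not tell whether the same exchange would give a similar step on the chloro-bearing core of compound 2. On these data alone, a carboxylic acid or a primary amide in place of the methoxycarbonyl group, and a plain phenyl on the amide-type nitrogen, remain open on this read-out.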